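A Fluorobenzyl Swap Without a Measured Starting Point

The source may report more compounds than this note shows. Statements on the series, on what has been measured and on what is new or still open speak of the compounds shown alone.

Among the compounds with values here, four compounds built on a shared core are considered here, but only one has a usable number in an ADME assay on microsomes from liver (Homo sapiens) for metabolic stability, with a stated time of 30 min; a lower number here means that less of the compound is left, a higher number that more of the compound is left. In that assay, compound 1 (`COc1nc2c(cc1Cc1cccc(Cl)c1F)c(=O)c(C(=O)O)cn2[C@H](CO)C(C)(C)C`) gives 82%. The result for compound 2 (`COc1nc2c(cc1Nc1ccc(F)cc1)c(=O)c(C(=O)O)cn2[C@H](CO)C(C)C`) is "not determined" (no result reported), so compound 2 has no single number and cannot be ranked against compound 1. The result for compound 3 (`COc1nc2c(cc1NCc1ccc(F)cc1)c(=O)c(C(=O)O)cn2[C@H](CO)C(C)(C)C`) is also "not determined" (no result reported), so it provides no nearby reference either.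

The compound still to be measured is compound 4 (`COc1nc2c(cc1NCc1ccccc1F)c(=O)c(C(=O)O)cn2[C@H](CO)C(C)C`). The structural change is 2-fluorobenzyl in place of 4-fluorophenyl on a nitrogen on an aromatic ring. In words, 2-fluorobenzyl takes the place of 4-fluorophenyl on a nitrogen on an aromatic ring, turning (4-fluorophenyl)amino into (2-fluorobenzyl)amino.

With no starting number, the size of this step in this assay cannot be read from the data, and no direction is favoured. The working expectation is therefore no step beyond the usual scatter. Within the data shown here, the only numerical anchor is compound 1 at 82%, and it differs from compound 4 in more than one place, so the estimate sits somewhat lower and stays wide. For compound 4, the percentage remaining is expected to be 72%, with an estimated range from 48% to 93%.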

Compound 4, percent of the compound remaining: 97%
Beside the measured number, compound 4's estimate is 25 percentage points below it; measured number outside the range, above it.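

In this assay, within the data shown here, compound 4 gives 97% while compound 2 has no single number there, and no step between the two can be read. The compounds shown leave open what 2-fluorobenzyl in place of 4-fluorophenyl does on its own to the percentage remaining. No further evidence bears on this result.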